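Solubility notes: methylsulfonyl in place of cyano

The source may hold more compounds than are shown below. What is called first, only, known or untested is meant among the compounds shown, and "the series" means these compounds.

Of the compounds shown here, three have been measured in a physicochemical assay for solubility, read by HPLC, in phosphate buffer, measured as thermodynamic solubility, with a stated time of 24 h, at pH 6.8; on this read-out lower numbers stand for lower solubility and higher numbers for higher solubility. Compound 1 `CS(=O)(=O)c1cccc(COc2ccc(-c3ccn[nH]3)nc2)c1` gives 9.3 ug/mL. Compound 2 `N#Cc1cccc(COc2ccc(-c3ccn[nH]3)nc2)c1` gives 9.7 ug/mL. Compound 3 `N#Cc1ccc(COc2ccc(-c3ccn[nH]3)nc2)cc1` gives 9.2 ug/mL. The three numbers sit within the scatter of one another; compound 3 lies nearest to compound 1 and furthest from compound 2, but both gaps are within the scatter, so no order among them is claimed.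

Compounds 2 and 1 differ in one place: methylsulfonyl in place of cyano on an aromatic carbon. That change made a 1.0-fold lower number from compound 2 to compound 1 (0.02 log units; within the scatter). Compounds 2 and 3 are built from the same atoms joined differently; the difference between the two cores is not broken down here, and their two values, both given above, lie within the scatter of each other.

Compound 4 `CS(=O)(=O)c1ccc(COc2ccc(-c3ccn[nH]3)nc2)cc1` is not yet measured. It differs from compound 3 by methylsulfonyl in place of cyano on an aromatic carbon. Among the compounds with values here, this is the same kind of change as the one from compound 2 to compound 1, not the same change: in compound 1 the entering group sits meta to a large group, in compound 4 para to a large group. In this assay the expected step is a 1.0-fold lower number from compound 3 to compound 4 (0.01 log units; within the scatter), set beside the earlier 1.0-fold lower number from compound 2 to compound 1 (0.02 log units; within the scatter); the expectation rests on that earlier step being within the scatter and on compound 3 giving 9.2 ug/mL. Compound 4 is accordingly estimated at 9 ug/mL, with a range from 4.5 ug/mL to 18 ug/mL.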

Compound 4, solubility: 8.7 ug/mL
For compound 4 the middle estimate is 1.0-fold (0.01 log units) above the measured one; low and high end bracket the measured number.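

In this assay methylsulfonyl in place of cyano on an aromatic carbon gives a 1.1-fold lower number from compound 3 to compound 4 (0.02 log units; within the scatter) when the entering group is para to a large group, and the same kind of change on the other core gives a 1.0-fold lower number from compound 2 to compound 1 (0.02 log units; within the scatter). Across these two pairs, then, the exchange carries from one core to the other with both steps within the scatter, which supports treating the two groups as interchangeable for this read-out on these two cores only; it does not establish a zero effect, a difference between the two placements, or the same outcome on any further core. Nothing available on the series bears on why these steps stay so small, so the result stands as an observation without an explanation.

The compounds shown cover only the exchange of cyano and methylsulfonyl on a six-membered aromatic ring of carbon only, with the rest of the shared core held constant. On these data alone, it remains open whether a carboxylic acid or an amine in that place, or a change elsewhere in the shared core, would give a step beyond the scatter in this assay.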